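Replacing the Propargyl Chain with a Methylsulfanylpropyl Chain

The source may hold more compounds than are shown below. What is called first, only, known or untested is meant among the compounds shown, and "the series" means these compounds.

Measured compounds:
compound 1, `CC(C)(C)c1ccc2nc(N)sc2c1`, gives 4 mg/kg in a functional assay on the whole organism with Rattus norvegicus as the target; on this read-out higher numbers stand for an effect only at larger amounts of compound and lower numbers for an effect already at smaller amounts
compound 2, `CCCCCc1ccc2nc(N)sc2c1`, gives 7.5 mg/kg in this assay
compound 3, `C#CCn1c(=N)sc2cc(OC(F)(F)F)ccc21`, gives 4 mg/kg in this assay

Compound 3 sits level with compound 1 at the digits shown, and the value of compound 2 lies somewhat higher, but the two values of compound 3 and compound 2 stay within the usual scatter of each other. The unmeasured compound 4 is `CSCCCn1c(=N)sc2cc(OC(F)(F)F)ccc21`. Its change from compound 3 is 2-(methylsulfanyl)ethyl in place of ethynyl on a saturated chain carbon bound to an aromatic nitrogen.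

Among the measured compounds shown here, only one measured step exists, a 1.9-fold higher number from compound 1 to compound 2 (0.27 log units; within the scatter), and it touches a group on an aromatic carbon of the shared core, not the chain on the ring nitrogen; it also stayed within the scatter. For the measured compounds named here, no measured step therefore speaks directly to the change from compound 3 to compound 4, and nothing among the measured compounds points to a large effect of altering that chain. The expected step is a 1.3-fold higher number from compound 3 to compound 4 (0.10 log units; within the scatter), which is none beyond the scatter. Compound 4 is therefore estimated at 5 mg/kg, with a range from 2 mg/kg to 15 mg/kg.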

Compound 4, dose for half-maximal effect: 4.2 mg/kg
Beside the measured number, compound 4's estimate is 1.2-fold (0.08 log units) above it; the measured number falls inside the stated range.
By their numbers in this assay, from the lowest: compounds 1, 3, 4 and 2 (each within the scatter of the next).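

Among the compounds shown here, this is the first measured step at the chain on the aromatic nitrogen, since the earlier step concerned a group on an aromatic carbon of the shared core. In this assay the change from propargyl to 3-(methylsulfanyl)propyl gives a 1.1-fold higher number from compound 3 to compound 4 (0.02 log units; within the scatter), so in this pair the triple bond can leave and a sulfur-bearing chain can enter with no difference beyond the scatter of this whole-animal read-out. Nothing shown here gives a measured property that would explain why the two chains read alike.

The compounds shown leave open whether a plain propyl chain, a longer chain, or a chain ending in an amine or a carboxylic acid would also stay within the scatter of compound 3. They also leave open whether the same swap would read alike on a core carrying tert-butyl or pentyl in place of trifluoromethoxy.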